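Chain length at the acid end of the bicyclic core

The source may report more compounds than this note shows. Statements on the series, on what has been measured and on what is new or still open speak of the compounds shown alone.

In a functional assay on CHO cells for agonist activity at prostaglandin E2 receptor EP3 subtype (Homo sapiens), read by fluorescence and calcium flux (on this read-out lower numbers stand for an effect already at smaller amounts and higher numbers for an effect only at larger amounts of compound), compound 3 `O=C(O)CC[C@H]1CC[C@@H]2[C@@H](/C=C/[C@@H](O)COc3ccccc3)[C@H](O)C[C@@H]2OC1` gives 4800 nM, which is the second highest of the three numbers measured. Compound 1 `O=C(O)CCC/C=C\C[C@@H]1[C@@H](/C=C/[C@@H](O)CCc2ccccc2)[C@H](O)C[C@@H]1O` gives 8600 nM in this assay, and compound 2 `O=C(O)CC[C@@H]1CC[C@@H]2[C@@H](/C=C/[C@@H](O)COc3ccccc3)[C@H](O)C[C@@H]2OC1` gives 870 nM. Among the measured compounds shown here, the only step between two compounds that differ in one place is a 5.5-fold higher number from compound 2 to compound 3 (0.74 log units; beyond the scatter), and that step rests on (the fact that compounds 2 and 3 differ only in the configuration as drawn).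

Compound 4 `O=C(O)CCC[C@H]1CC[C@@H]2[C@@H](/C=C/[C@@H](O)COc3ccccc3)[C@H](O)C[C@@H]2OC1` differs from compound 3 in a different way: carboxymethyl in place of carboxy on a saturated chain carbon, two bonds along the chain from a saturated ring carbon. For the measured compounds named here, none of the measured steps changes the length of this chain, so no measured step bears on the change from compound 3 to compound 4. The step from compound 2 to compound 3 concerns configuration alone and gives no guide here.

With nothing to point in either direction, the step of a 1.1-fold lower number from compound 3 to compound 4 (0.03 log units; within the scatter) is expected to stay within the usual scatter. Compound 4 is therefore estimated at 4500 nM in this assay, with a range from 1200 nM to 17000 nM.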

Compound 4, half-maximal effective concentration: 4 nM
Compound 4: middle estimate off by 1100-fold (3.05 log units), on the high side, and the stated range ends above it.
By their numbers in this assay, from the lowest: compound 4; then compound 2; then compounds 3 and 1 (each within the scatter of the next).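

Lengthening the acid-bearing chain from 2-carboxyethyl to 3-carboxypropyl gives a 1200-fold lower number from compound 3 to compound 4 (3.08 log units; beyond the scatter), so the length of this chain has a very large effect in this assay. The earlier compounds shown here showed only that the drawn configuration at a saturated ring carbon matters, with a 5.5-fold higher number from compound 2 to compound 3 (0.74 log units; beyond the scatter), a far smaller step that said nothing about chain length. The evidence at hand does not explain why this change has so large an effect.

Going by these compounds, whether a longer chain, such as 4-carboxybutyl, would lower the number further or raise it again remains open. So does whether the configuration drawn in compound 2 would change the number when paired with the 3-carboxypropyl chain.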